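Notes on the step from compound 1 to compound 3

This account rests on a few compounds, and the source may have more. Where it says the series, first, only, none or still open, it means among the compounds named here.

In a functional assay on HCT-116 cells (Homo sapiens) for cytotoxicity, read by MTT assay, with a stated time of 72 h (on this read-out lower numbers stand for stronger inhibition and higher numbers for weaker inhibition), compound 1 (`[O-][S+](CCCCN=C=S)Cc1ccccc1`) gives 3660 nM and compound 2 (`COc1ccc(C[S+]([O-])CCCCN=C=S)cc1`) gives 5460 nM. Compound 1 has only compound 2 to stand against, and the two values lie within the scatter of each other.

Compound 3 (`[O-][S+](CCCN=C=S)Cc1ccccc1`) has not yet been measured in this assay. Its difference from compound 1 is a group of 3 heavy atoms (1 carbon, 1 nitrogen, 1 sulfur; no ring) in place of a group of 4 heavy atoms (2 carbon, 1 nitrogen, 1 sulfur; no ring), on a saturated chain carbon, three bonds along the chain from a sulfur: a group of 3 heavy atoms in place of a group of 4 heavy atoms, on a saturated chain carbon, three bonds along the chain from a sulfur.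

Within the data shown here, the only measured step is a 1.5-fold higher number from compound 1 to compound 2 (0.17 log units; within the scatter), which lies within the scatter. It is methoxy in place of hydrogen on an aromatic carbon, a different kind of change, so it bears only indirectly. Among the measured compounds shown here, no measured step tests the chain change itself. No step beyond the scatter is therefore expected in this assay, and the direction remains poorly defined. The expected step is a 1.2-fold higher number from compound 1 to compound 3 (0.09 log units; within the scatter). For compound 3 the estimated value is 4500 nM, with an expected range of 2000 nM to 10000 nM.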

Compound 3, half-maximal inhibitory concentration: 15600 nM
For compound 3 the middle estimate is 3.5-fold (0.54 log units) below the measured one; the measured number lies above the stated range.
By their numbers in this assay, from the lowest: compounds 1 and 2 (each within the scatter of the next); then compound 3.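

In this assay, among these compounds, the chain change is the first single change in this short series to give a step beyond the scatter: the group of 3 heavy atoms in place of the group of 4 heavy atoms gives a 4.3-fold higher number from compound 1 to compound 3 (0.63 log units; beyond the scatter). The step is modest, but it runs toward weaker inhibition and so marks this place, on a saturated chain carbon, three bonds along the chain from a sulfur, as one where a change in the group can register in this read-out, which methoxy in place of hydrogen on an aromatic carbon, with a 1.5-fold higher number from compound 1 to compound 2 (0.17 log units; within the scatter), did not show. Nothing at hand bears on what lies behind the step.

Two compounds differing only in this group cannot show whether the number follows chain length in general, and a longer chain at this place could leave it level, lower or higher. Also open, on these data alone, are whether the step carries over to the methoxy-bearing compound 2 and how an amine in place of the group of 4 heavy atoms would read.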